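From Free Amine to Bromoacrylamide on the Shared Core

The compounds below may be only part of what the source reports. "The series", "measured", "known", "first", "only" and "open" are said of these compounds alone.

Going by the values given here, compound 3 `COc1ccc(-c2nn3cc(-c4cccc(N)c4)nc3s2)cc1` is the one compound here that gives no number in a functional assay on L1210 cells (Mus musculus) for inhibition, read by cell counting, with a stated time of 2 days (on this read-out higher numbers stand for weaker inhibition and lower numbers for stronger inhibition), but only a limit, >= 250000 nM, which is the limit of >= 250000 nM in this assay, at which 1 of the 3 values shown sits. Compound 1 `C=C(Br)C(=O)Nc1cccc(-c2cn3nc(-c4ccc(F)cc4)sc3n2)c1` gives 250 nM, and compound 2 `C=C(Br)C(=O)Nc1cccc(-c2cn3nc(-c4ccc(OCC)cc4)sc3n2)c1` gives 790 nM; both carry the (1-bromoethenyl)carbonyl group on the nitrogen. Among the compounds with values here, the only measured step, a 3.2-fold higher number from compound 1 to compound 2 (0.50 log units; beyond the scatter), changes the group on the aromatic carbon, so no measured step covers the change at the nitrogen itself. Compound 4 `C=C(Br)C(=O)Nc1cccc(-c2cn3nc(-c4ccc(OC)cc4)sc3n2)c1` differs from compound 3 by (1-bromoethenyl)carbonyl in place of hydrogen on a nitrogen on an aromatic ring. Because compound 1, which carries this group, gives 250 nM, a large fall in the number, far beyond the scatter, is expected. Compound 4 is expected near 400 nM, between 150 nM and 1500 nM. This amounts to an expected at least 620-fold lower number from compound 3 to compound 4 (2.79 log units; beyond the scatter).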

Compound 4, half-maximal inhibitory concentration: 940 nM
Beside the measured number, compound 4's estimate is 2.4-fold (0.37 log units) below it, and the stated range covers the measured number.
By their numbers in this assay, from the lowest: compound 1; then compounds 2 and 4 (each within the scatter of the next). At a limit, above all of these: compound 3.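

In this assay, going by these compounds alone, (1-bromoethenyl)carbonyl in place of hydrogen on the nitrogen gives the first measured change at this position: an at least 260-fold lower number from compound 3 to compound 4 (2.42 log units; beyond the scatter). Compound 3 stands only at a limit, so that size is a floor: the limit of >= 250000 nM in this assay, at which 1 of the 4 values shown sits. On the aromatic carbon, methoxy and ethoxy cannot be told apart, with a 1.2-fold higher number from compound 2 to compound 4 (0.08 log units; within the scatter), whereas fluoro gives the lowest number, with a 3.8-fold higher number from compound 1 to compound 4 (0.58 log units; beyond the scatter).

The compounds shown leave open whether acetyl or plain acryloyl on the same nitrogen would give similar numbers. As far as these compounds go, how an amine or a carboxylic acid would read in place of fluoro on the aromatic carbon also stays open.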